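The source may report more compounds than this note shows. Statements on the series, on what has been measured and on what is new or still open speak of the compounds shown alone.

Values in a functional assay on DU-145 cells (Homo sapiens) for cytotoxicity, read by sulforhodamine B assay; on this read-out lower numbers stand for stronger inhibition of growth and higher numbers for weaker inhibition of growth:

compound 1 `Cc1ccc2c(c1)CCCN2c1nc(Cl)nc2ccccc12` gives 57 nM
compound 2 `Cc1ccc2c(c1)CCCN2c1nc(C)nc2ccccc12` gives 187 nM
compound 3 `COc1ccc2c(c1)C(=O)CCN2c1nc(Cl)nc2ccccc12` gives 31 nM

At the start of this step stands compound 3. Compound 3 at 31 nM cannot be told apart from compound 1 at 57 nM once the usual scatter of repeated measurements is allowed for. Compound 2 at 187 nM carries a clearly higher number than either of them, and so inhibits growth more weakly.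

The compound in question is compound 4 `COc1ccc2c(c1)C(=O)CCN2c1nc(C)nc2ccccc12` which differs from compound 3 in one place: methyl in place of chloro on an aromatic carbon on the aromatic carbon between two ring nitrogen atoms.

Among the measured compounds shown here, only one measured step bears on this change. The identical exchange at the same place gave a 3.3-fold higher number from compound 1 to compound 2 (0.52 log units; beyond the scatter) and that move was modest but beyond the scatter. The rest of compound 1 differs from the rest of compound 3, and a single pair is thin evidence, so the size may not carry over exactly. A rise of similar size is still the reasonable expectation, which means weaker growth inhibition.

The estimated change is a 3.1-fold higher number from compound 3 to compound 4 (0.49 log units; beyond the scatter) in this assay on this reasoning.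

Compound 4 is expected at 95 nM with an estimated range from 40 nM to 230 nM in this reading.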

Compound 4, concentration for 50% growth inhibition: 21 nM
Estimate against measurement, compound 4: 4.5-fold (0.66 log units) above, outside the stated range (below it).
By their numbers in this assay, from the lowest: compounds 4, 3 and 1 (each within the scatter of the next, the first and the last beyond it); then compound 2.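

In this assay the exchange of chloro for methyl on the aromatic carbon between two ring nitrogen atoms has no single fixed effect. On the core that carries methoxy and a ring carbonyl it gives a 1.5-fold lower number from compound 3 to compound 4 (0.17 log units; within the scatter) and so leaves no detectable loss of growth inhibition, whereas the earlier pair alone pointed to a clear loss, which now holds only for the core of compound 1. What this change does at this place therefore depends on the rest of the molecule, as the two steps show: the same change on two cores in this assay, a 3.3-fold higher number (0.52 log units; beyond the scatter) from compound 1 to compound 2 and a 1.5-fold lower number (0.17 log units; within the scatter) from compound 3 to compound 4, 4.8-fold (0.69 log units) apart, beyond the scatter of two such steps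

Compound 1 and compound 3 differ in more than one place, and the compounds shown do not tell which of those differences separates the two steps. On these data alone, whether an amine, a hydroxyl or a longer chain such as propyl on this same carbon would also keep growth inhibition in this range on either core remains open.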